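The source may hold more compounds than are shown below. What is called first, only, known or untested is meant among the compounds shown, and "the series" means these compounds.

Compound 1, with the structure `Oc1ccc(-c2cc(-c3ccccc3)cc(-c3cccs3)n2)cc1`, was tested in a functional assay on DU-145 cells (Homo sapiens) for cytotoxicity, read by ELISA, with a stated time of 2 days (on this read-out lower numbers stand for stronger inhibition and higher numbers for weaker inhibition), where compound 1 gives 3700 nM. Compound 2, `Oc1ccc(-c2cc(-c3ccccc3)cc(-c3ccsc3)n2)cc1`, carries the change thiophen-3-yl in place of thiophen-2-yl on an aromatic carbon relative to compound 1, and in this assay compound 2 gives 8500 nM; the step of a 2.3-fold higher number from compound 1 to compound 2 (0.36 log units; beyond the scatter) is a modest one. Compound 3, `Oc1cccc(-c2cc(-c3ccccc3)nc(-c3cccs3)c2)c1`, gives 19700 nM in this assay, the highest of the three numbers, with compound 2 nearest to it and compound 1 furthest. The difference between the core of compound 3 and the core of compound 1 is not broken down here.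

Compound 4, `Oc1cccc(-c2cc(-c3ccccc3)nc(-c3ccsc3)c2)c1`, has not yet been measured. It differs from compound 3 by thiophen-3-yl in place of thiophen-2-yl on an aromatic carbon. Among the compounds with values here, this is the same kind of change as the one from compound 1 to compound 2, but the surroundings are not identical: in compound 1 the site is meta to a 4-hydroxyphenyl group, whereas in compound 3 it is meta to a 3-hydroxyphenyl group. Within the data shown here, with only one example of this change measured, the expectation for compound 4 rests on that single step. Compound 4 is expected to show a step of a 2.3-fold higher number from compound 3 to compound 4 (0.36 log units; beyond the scatter) in this assay, of similar size to a 2.3-fold higher number from compound 1 to compound 2 (0.36 log units; beyond the scatter), because compound 3 already gives 19700 nM and the earlier change made the number higher. Compound 4 is therefore estimated at 45000 nM in this assay, with a range from 15000 nM to 120000 nM that allows for the change acting differently around a 3-hydroxyphenyl group.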

Compound 4, half-maximal inhibitory concentration: 11700 nM
Beside the measured number, compound 4's estimate is 3.8-fold (0.59 log units) above it; the whole stated range lies above it.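

Within the data shown here, on the second core, thiophen-3-yl in place of thiophen-2-yl gives a 1.7-fold lower number from compound 3 to compound 4 (0.23 log units; within the scatter) in this assay, so this pair cannot be told apart on this read-out, whereas the same change on the first core gave a step beyond the scatter. The change therefore did not carry over from one core to the other with its size intact, and the two steps differ by more than repeated measurements would explain: the same change on two cores in this assay, a 2.3-fold higher number (0.36 log units; beyond the scatter) from compound 1 to compound 2 and a 1.7-fold lower number (0.23 log units; within the scatter) from compound 3 to compound 4, 3.9-fold (0.59 log units) apart, beyond the scatter of two such steps. Among these compounds, this shows that, in this series, the step measured on one core cannot be taken as a guide to the other, but with only two matched pairs in a single cell assay it gives no rule for other cores and does not show what in the cores sets the two steps apart.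

The compounds shown leave open how the thiophene swap would behave if the hydroxyl on the phenyl ring were replaced by a methoxy group or an amine, and whether a furan or a pyridine ring in place of the thiophene would follow either step. They also leave open whether the difference between the two steps would hold in any cell line other than the one used here.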